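Dichloro-methyl aryl variant of a coumarin-triazine agonist

The source may hold more compounds than are shown below. What is called first, only, known or untested is meant among the compounds shown, and "the series" means these compounds.

Measured compounds:
compound 1 `Cc1ccc(Nc2nc(N)nc(COc3ccc4c(C)cc(=O)oc4c3)n2)cc1`, 1790 nM
compound 2 `Cc1cc(=O)oc2cc(OCc3nc(N)nc(Nc4cccc(Cl)c4)n3)ccc12`, 1110 nM
compound 3 `Cc1cc(=O)oc2cc(OCc3nc(N)nc(Nc4ccc(C(C)C)cc4)n3)ccc12`, 460 nM

In an assay on COS-7 cells for agonist activity at Free fatty acid receptor 1 (Homo sapiens), read by scintillation counting and inositol phosphate accumulation, with a stated time of 90 min (a higher number here means that more compound is needed for the effect, a lower number that less compound is needed), compound 2 gives 1110 nM. Its number and that of compound 1 lie within the scatter of each other, while compound 3 gives a lower number, a step of a 2.4-fold lower number from compound 2 to compound 3 (0.38 log units; beyond the scatter). Compound 4 `Cc1c(Cl)cc(Nc2nc(N)nc(COc3ccc4c(C)cc(=O)oc4c3)n2)cc1Cl` differs from compound 2 by 3,5-dichloro-4-methylphenyl in place of 3-chlorophenyl on a nitrogen on an aromatic ring. Going by the values given here, no measured step makes this exact change; the nearest guides are a 3.9-fold lower number from compound 1 to compound 3 (0.59 log units; beyond the scatter) and a 2.4-fold lower number from compound 2 to compound 3 (0.38 log units; beyond the scatter), where a larger group on the phenyl ring went with a lower number. By analogy a modest lowering is expected, a 1.7-fold lower number from compound 2 to compound 4 (0.23 log units; within the scatter), so compound 4 is estimated at 650 nM, within 250 nM to 1700 nM.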

Compound 4, half-maximal effective concentration: 600 nM
Estimate against measurement, compound 4: 1.1-fold (0.03 log units) above; measured number inside the range.
By their numbers in this assay, from the lowest: compounds 3, 4, 2 and 1 (each within the scatter of the next, the first and the last beyond it).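

In this assay, a phenyl ring on this nitrogen can carry two chlorines and a methyl together, with a 3.0-fold lower number from compound 1 to compound 4 (0.47 log units; beyond the scatter) against the methyl-only ring, while the single-chlorine ring gives only a 1.9-fold lower number from compound 2 to compound 4 (0.27 log units; within the scatter). Against the isopropyl ring there is a 1.3-fold higher number from compound 3 to compound 4 (0.12 log units; within the scatter), so 3,5-dichloro-4-methylphenyl and 4-isopropylphenyl cannot be told apart here. Nothing available explains these steps. Still open, as far as these compounds go, is how a phenyl ring carrying a carboxylic acid, an amine or a methoxy group would behave on this nitrogen.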